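The compounds below may be only part of what the source reports. "The series", "measured", "known", "first", "only" and "open" are said of these compounds alone.

Measured compounds:
compound 1, `CCCCCCCCCCCCOC(=O)CCC(=O)N1CCN(CCCOc2cc3c(Nc4ccc(F)c(Cl)c4)ncnc3cc2OC)CC1` — a functional assay on A549 cells (Homo sapiens) for cytotoxicity, read by MTT assay, with a stated time of 24 h, tested at 20 uM; on this read-out higher numbers stand for a weaker effect at the one concentration tested and lower numbers for a stronger effect: 86.8%
compound 2, `CCCCCCCCCCCCCOC(=O)CCC(=O)N1CCN(CCCOc2cc3c(Nc4ccc(F)c(Cl)c4)ncnc3cc2OC)CC1` — this assay: 93.8%

Among the measured compounds shown here, on these two numbers compound 2 stands highest, with compound 1 as its nearest neighbour; the only step so far is a number 7 percentage points higher from compound 1 to compound 2 (within the scatter), which lengthens the ester chain by one carbon at the far end and leaves the read-out essentially unchanged.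

Compound 3, `CCCCCCCCCCCCCCCCOC(=O)CCC(=O)N1CCN(CCCOc2cc3c(Nc4ccc(F)c(Cl)c4)ncnc3cc2OC)CC1`, extends the same chain further: propyl in place of hydrogen on a saturated chain carbon, ten or more bonds along the chain from an oxygen next to a carbonyl group. For the measured compounds named here, the one step that bears on it is the chain extension from compound 1 to compound 2, and that step was within the scatter. With the ester chain already long in compound 2 and nothing in the data pointing to a change, the expected step is a number 0.2 percentage points higher from compound 2 to compound 3 (within the scatter), that is, no movement beyond the scatter.

Compound 3 is therefore estimated at 94%, with a range of 82% to 106%.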

Compound 3, a percentage reported as activity, at one concentration (the size of the read-out at that concentration, not a potency): 91.7%
Beside the measured number, compound 3's estimate is 2.3 percentage points above it, within the range that was stated.
By their numbers in this assay, from the lowest: compounds 1, 3 and 2 (each within the scatter of the next).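

Propyl in place of hydrogen on the saturated chain carbon gives a number 2.1 percentage points lower from compound 2 to compound 3 (within the scatter) in this assay, and butyl at the same place gives a number 4.9 percentage points higher from compound 1 to compound 3 (within the scatter). With these steps, the larger replacements join methyl in staying within the scatter, so across the three chain lengths shown, this position does not separate the compounds on this read-out, and the chain extension has no resolved effect here. No other data bear on this result.

As far as these compounds go, whether a much shorter chain, or an amine or a carboxylic acid at the far end of the chain, would shift the read-out beyond the scatter remains open. The compounds shown also leave open whether the lack of separation would hold at other concentrations, as a single concentration gives no potency for any of them.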